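From hept-1-en-1-yl to 3-pentyloxiran-2-yl on the shared core

The source may hold more compounds than are shown below. What is called first, only, known or untested is meant among the compounds shown, and "the series" means these compounds.

In a functional assay on A-431 cells (Homo sapiens) for inhibition (on this read-out lower numbers stand for stronger inhibition and higher numbers for weaker inhibition), compound 1 `CCCCCC#C[C@@]1(C)O[C@@H]2OC(=O)N(C(=O)CCl)[C@@H]2CC1=O` gives 47000 nM, compound 2 `COC#C[C@@]1(C)O[C@@H]2OC(=O)N(C(=O)CCl)[C@@H]2CC1=O` gives 64000 nM and compound 3 `CCCCC/C=C/[C@@]1(C)O[C@@H]2OC(=O)N(C(=O)CCl)[C@@H]2CC1=O` gives 81000 nM. Compound 3 stands within the scatter of both other compounds, so these numbers set no order among the three.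

Next is compound 4 `CCCCCC1OC1[C@@]1(C)O[C@@H]2OC(=O)N(C(=O)CCl)[C@@H]2CC1=O`, with 3-pentyloxiran-2-yl in place of hept-1-en-1-yl on a saturated ring carbon.

Among the measured compounds shown here, no measured step makes this exact change, and none of the measured compounds carries a three-membered ring. The nearest evidence is the replacement of hept-1-yn-1-yl by hept-1-en-1-yl, a 1.7-fold higher number from compound 1 to compound 3 (0.24 log units; within the scatter). The replacement of 2-methoxyethynyl by hept-1-en-1-yl gives a 1.3-fold higher number from compound 2 to compound 3 (0.10 log units; within the scatter), and methoxy in place of pentyl on a triple-bonded carbon gives a 1.4-fold higher number from compound 1 to compound 2 (0.13 log units; within the scatter). All three steps are small and stay within the scatter, so no step beyond the scatter is expected in this assay, and no direction can be argued from them. The expected change is a 1.4-fold lower number from compound 3 to compound 4 (0.13 log units; within the scatter). Compound 4 is estimated at 60000 nM, with an expected range of 25000 nM to 130000 nM.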

Compound 4, half-maximal inhibitory concentration: 116000 nM
Estimate against measurement, compound 4: 1.9-fold (0.29 log units) below; low and high end bracket the measured number.
By their numbers in this assay, from the lowest: compounds 1, 2, 3 and 4 (each within the scatter of the next, the first and the last beyond it).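

In this assay, putting the three-membered ring of 3-pentyloxiran-2-yl on this saturated ring carbon next to the ring oxygen adds a hydrogen-bond acceptor, yet the exchange for hept-1-en-1-yl gives a 1.4-fold higher number from compound 3 to compound 4 (0.16 log units; within the scatter) and the exchange for 2-methoxyethynyl gives a 1.8-fold higher number from compound 2 to compound 4 (0.26 log units; within the scatter), so neither step separates the groups. Among the compounds shown here, only the exchange for hept-1-yn-1-yl goes beyond the scatter, with a 2.5-fold higher number from compound 1 to compound 4 (0.39 log units; beyond the scatter), which is modest and is the first step at this position to separate two groups, although compound 3 and compound 2 still lie within the scatter of compound 4. Nothing available on these compounds accounts for that single step.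

Every group shown at this position is a seven-carbon chain or a short methoxy-capped alkyne, all uncharged, so the effect of an amine, a carboxylic acid or a longer chain in this place remains open. The structure of compound 4 also gives no configuration for the three-membered ring, so any difference between its stereoisomers in this read-out is unresolved.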